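The compounds below may be only part of what the source reports. "The series", "measured", "known", "first", "only" and "open" are said of these compounds alone.

Compound 1, `O=C(O)CCC(=O)Nc1ccc(-c2nc3cc(C(F)(F)F)ccc3[nH]2)cc1`, is the starting point of this step. In an ADME assay on Vero cells (Chlorocebus sabaeus) for cytotoxicity (on this read-out higher numbers stand for lower toxicity in this test and lower numbers for higher toxicity in this test), compound 1 gives > 100000 nM, and this is a limit of the test rather than a measured number, as the limit of > 100000 nM in this assay, at which 1 of the 2 values shown sits, shows. A second measured member of the series is compound 2, `COc1cc(-c2nc3cc(C(F)(F)F)ccc3[nH]2)cc(OC)c1OC`, and in this assay compound 2 gives 29000 nM; no single-place change links it to compound 1, so the two values stand side by side without a computed step. The unmeasured compound 3, `O=C(CCl)Nc1ccc(-c2nc3cc(C(F)(F)F)ccc3[nH]2)cc1`, differs from compound 1 at one place: chloro in place of carboxymethyl on a saturated chain carbon bound to a carbonyl carbon. Among the measured compounds shown here, no measured pair shows this change, so its effect is unknown from the data. The step of an at least 5.0-fold lower number from compound 1 to compound 3 (0.69 log units; beyond the scatter) is expected to go toward lower values, beyond the usual scatter. Compound 3 is therefore estimated at 20000 nM, within a range from 3000 nM to 100000 nM.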

Compound 3, half-maximal cytotoxic concentration: 35000 nM
Estimate against measurement, compound 3: 1.8-fold (0.24 log units) below; low and high end bracket the measured number.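

In this assay, among the compounds shown here, this is the first measured step at this position, with chloro in place of carboxymethyl on a saturated chain carbon bound to a carbonyl carbon: an at least 2.8-fold lower number from compound 1 to compound 3 (0.45 log units; beyond the scatter). The position therefore matters for this read-out, and this change moves it toward higher toxicity in this test, beyond the usual scatter. From the compounds shown here alone, the full size of the step stays unknown because the value for compound 1 is a limit and not a number: the limit of > 100000 nM in this assay, at which 1 of the 3 values shown sits.

One change cannot separate the effect of adding chloro from the effect of removing carboxymethyl. A methyl or an amine at the same place would help show whether the lower number goes with chloro itself or with any group that replaces carboxymethyl.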